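Shortening the Aryl Chain by One Carbon

The compounds below may be only part of what the source reports. "The series", "measured", "known", "first", "only" and "open" are said of these compounds alone.

Measured compounds:
compound 1 `CCCCCCC#Cc1cn(C/C=C/CN2C(=O)c3ccccc3C2=O)c(=O)[nH]c1=O`: 14000 nM
compound 2 `CCCCCC#Cc1cn(C/C=C/CN2C(=O)c3ccccc3C2=O)c(=O)[nH]c1=O`: 9000 nM
compound 3 `CCCCCc1ccc(C#Cc2cn(C/C=C/CN3C(=O)c4ccccc4C3=O)c(=O)[nH]c2=O)cc1`: 4300 nM

In a functional assay on HepG2 cells (Homo sapiens) for antiproliferative activity, read by MTT assay, with a stated time of 3 days (a lower number here means a stronger inhibitor, a higher number a weaker inhibitor), compound 3 gives the lowest number of the three; the steps toward it are a 3.3-fold lower number from compound 1 to compound 3 (0.51 log units; beyond the scatter) and a 2.1-fold lower number from compound 2 to compound 3 (0.32 log units; beyond the scatter), both modest. Compound 4 `CCCCc1ccc(C#Cc2cn(C/C=C/CN3C(=O)c4ccccc4C3=O)c(=O)[nH]c2=O)cc1` differs from compound 3 by hydrogen in place of methyl on a saturated chain carbon, four bonds along the chain from an aromatic carbon. Among the measured compounds shown here, the only measured step of the same kind is a 1.6-fold lower number from compound 1 to compound 2 (0.19 log units; within the scatter), where a chain was likewise shortened by one carbon, though there the chain sat on a triple-bonded carbon rather than on a ring; that step stayed within the scatter. On that single precedent, compound 4 is expected to change little, the step being a 1.2-fold lower number from compound 3 to compound 4 (0.09 log units; within the scatter). Compound 4 is therefore estimated at 3500 nM, within a range of 1500 nM to 8000 nM.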

Compound 4, half-maximal inhibitory concentration: 9100 nM
Compound 4: middle estimate off by 2.6-fold (0.41 log units), on the low side, and the stated range ends below it.
By their numbers in this assay, from the lowest: compound 3; then compounds 2, 4 and 1 (each within the scatter of the next).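

Shortening a chain by one carbon does not carry over from one core to the other, so the earlier step gave a poor guide here: the same change on two cores in this assay, a 1.6-fold lower number (0.19 log units; within the scatter) from compound 1 to compound 2 and a 2.1-fold higher number (0.33 log units; beyond the scatter) from compound 3 to compound 4, 3.3-fold (0.52 log units) apart, beyond the scatter of two such steps. On the ring, then, chain length does register in this assay, with a 2.1-fold higher number from compound 3 to compound 4 (0.33 log units; beyond the scatter). The lower number seen with 4-pentylphenyl does not extend to 4-butylphenyl, whose steps from the plain chains are a 1.0-fold higher number from compound 2 to compound 4 (0.00 log units; within the scatter) and a 1.5-fold lower number from compound 1 to compound 4 (0.19 log units; within the scatter), both within the scatter.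

From the compounds shown here alone, whether 4-hexylphenyl, with a longer chain, would lower the number further remains open, as does the effect of an amine on that chain.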